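Pyridin-3-yl in Place of 3-Hydroxyphenyl: Expecting a Small Step

The compounds below may be only part of what the source reports. "The series", "measured", "known", "first", "only" and "open" are said of these compounds alone.

Compound 1 `CC(O)(C(=O)Nc1ccc(S(=O)(=O)c2cccc(O)c2)cc1)C(F)(F)F` is the only one of the three measured compounds for which this study gives a definite number. In a functional assay (Cavia porcellus) with sulfonylurea receptors; K-ATP channels (Homo sapiens) as the target (on this read-out lower numbers stand for stronger inhibition and higher numbers for weaker inhibition), compound 1 gives 18000 nM. Compound 2 `CC(O)(C(=O)Nc1ccc(S(=O)(=O)c2cccc(C(F)(F)F)c2)cc1)C(F)(F)F` carries trifluoromethyl in place of hydroxy on an aromatic carbon and reaches only the limit of this assay, > 30000 nM. Compound 3 `CO/N=C(/c1ccccc1)c1ccc(NC(=O)C(C)(O)C(F)(F)F)cc1`, built on a different core, likewise stops at the limit of this assay, > 30000 nM. Among the measured compounds shown here, the one step that can be computed, an at least 1.6-fold higher number from compound 1 to compound 2 (0.22 log units; that floor lies within the scatter), points toward a higher number when the hydroxy goes, but evidence is thin: the limit of > 30000 nM in this assay, at which 2 of the 3 values shown sit.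

Compound 4 `CC(O)(C(=O)Nc1ccc(S(=O)(=O)c2cccnc2)cc1)C(F)(F)F` differs from compound 1 in a single place: pyridin-3-yl in place of 3-hydroxyphenyl on a sulfonyl sulfur. As in compound 2, the hydroxy donor is lost; unlike compound 2, an acceptor ring nitrogen enters. For the measured compounds named here, the step from compound 1 to compound 2 is the only measured guide and it is only a floor. A step of modest size toward a higher number is therefore expected in this assay, with the limit of this assay a real possibility. Compound 4 is estimated to give 30000 nM in this assay, within 12000 nM to 80000 nM. This estimate means an expected step of a 1.7-fold higher number from compound 1 to compound 4 (0.22 log units; within the scatter).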

Compound 4, half-maximal inhibitory concentration: 3500 nM
Estimate against measurement, compound 4: 8.6-fold (0.93 log units) above, and the stated range ends above it.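

The sulfonyl sulfur turns out to tolerate a ring without a hydrogen-bond donor in this assay: pyridin-3-yl in place of 3-hydroxyphenyl gives a 5.1-fold lower number from compound 1 to compound 4 (0.71 log units; beyond the scatter), so inhibition becomes stronger rather than weaker. Among the compounds shown here, this is the first change at this position with a measured size beyond the scatter, since the earlier step there was only a floor within it. It also shows that losing the hydroxy does not by itself push the number higher, because what enters with that loss matters, although the only other comparison at this position cannot be read as a step, since it ends in a limit and not a number: the limit of > 30000 nM in this assay, at which 2 of the 4 values shown sit.

Because the whole ring changes in one step, the compounds shown cannot separate the loss of the hydroxy from the entry of the ring nitrogen, and they do not tell why the number falls. As far as these compounds go, it also remains open how this position would respond to an amine or a carboxylic acid on the ring, or to a plain unsubstituted phenyl group.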